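Working notes: azido in place of chloro

This account rests on a few compounds, and the source may have more. Where it says the series, first, only, none or still open, it means among the compounds named here.

Measured compounds:
- compound 1 `COc1ccc(CN(C(C)=O)c2cc(OC)c(OC)c(OC)c2)cc1O` gives 270 nM
- compound 2 `COc1ccc(CN(C(=O)C(C)Br)c2cc(OC)c(OC)c(OC)c2)cc1O` gives 140 nM
- compound 3 `COc1ccc(CN(C(=O)CCl)c2cc(OC)c(OC)c(OC)c2)cc1O` gives 250 nM

In a functional assay on HCT-116 cells (Homo sapiens) for inhibition, read by MTT assay, with a stated time of 48 h (a higher number here means a weaker inhibitor, a lower number a stronger inhibitor), compound 3 gives 250 nM and stands within the scatter of both other compounds, which also lie within the scatter of each other. Compound 4 `COc1ccc(CN(C(=O)CN=[N+]=[N-])c2cc(OC)c(OC)c(OC)c2)cc1O` has azido in place of chloro on a saturated chain carbon bound to a carbonyl carbon, with azido in place of chloro on a saturated chain carbon bound to a carbonyl carbon as the counted change. The closest evidence is a 1.1-fold lower number from compound 1 to compound 3 (0.03 log units; within the scatter) for chloro in place of hydrogen and a 1.8-fold higher number from compound 2 to compound 3 (0.25 log units; within the scatter) for chloromethyl in place of 1-bromoethyl, with a 1.9-fold lower number from compound 1 to compound 2 (0.29 log units; within the scatter) as the third step. Among the measured compounds shown here, no measured step involves azido, so no step beyond the scatter is expected, and the expected size is a 1.3-fold lower number from compound 3 to compound 4 (0.10 log units; within the scatter) for now. For compound 4 the estimated value is 200 nM with an expected range from 80 nM to 500 nM for now.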

Compound 4, half-maximal inhibitory concentration: 410 nM
Estimate against measurement, compound 4: 2.1-fold (0.31 log units) below, within the range that was stated.
By their numbers in this assay, from the lowest: compounds 2, 3, 1 and 4 (each within the scatter of the next, the first and the last beyond it).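

In this assay, azido on a saturated chain carbon bound to a carbonyl carbon stays within the scatter of both chloro (a 1.6-fold higher number from compound 3 to compound 4 (0.21 log units; within the scatter)) and hydrogen (a 1.5-fold higher number from compound 1 to compound 4 (0.18 log units; within the scatter)). Among the compounds shown here, the first step beyond the scatter is modest and comes with azidomethyl in place of 1-bromoethyl (a 2.9-fold higher number from compound 2 to compound 4 (0.47 log units; beyond the scatter)), a swap that cannot be assigned to azido alone. Nothing available accounts for these numbers.

Still open, as far as these compounds go, is whether an amine or a carboxylic acid at this carbon would also stay within the scatter of hydrogen. A 1-azidoethyl group would separate the azido from the extra methyl.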